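Cyclopropylcarbonyl in Place of Acetyl on a Benzothiazole Amide

This account rests on a few compounds, and the source may have more. Where it says the series, first, only, none or still open, it means among the compounds named here.

Compound 1 `COc1c(NS(=O)(=O)c2ccc(F)cc2)cc(-c2ccc3nc(NC(C)=O)sc3c2)cc1C(N)=O` gives 4750 nM in a functional assay on U-87MG ATCC cells (Homo sapiens) for antiproliferative activity, read by MTT assay, with a stated time of 72 h (on this read-out higher numbers stand for weaker inhibition and lower numbers for stronger inhibition), the lower of the two numbers measured. Compound 3 `COc1c(NS(=O)(=O)c2ccc(F)cc2)cc(-c2ccc3nc(NC(C)=O)sc3n2)cc1C(N)=O` gives 21700 nM, a weaker result that lies beyond the scatter. For compound 2 `COc1c(NS(=O)(=O)C2CC2)cc(-c2ccc3nc(NC(C)=O)nn3c2)cc1C(N)=O` the outcome is "not determined" (no result reported). The unmeasured compound 4 `COc1c(NS(=O)(=O)c2ccc(F)cc2)cc(-c2ccc3nc(NC(=O)C4CC4)sc3c2)cc1C(N)=O` differs from compound 1 by cyclopropyl in place of methyl on a carbonyl carbon. Among the compounds with values here, no measured pair shows this change, so the expectation rests on compound 1 alone, at 4750 nM, and on the small size of the change. The step from compound 1 to compound 4 is expected to be modest, a 1.4-fold lower number from compound 1 to compound 4 (0.13 log units; within the scatter), not clearly beyond the scatter. Compound 4 is therefore estimated at 3500 nM, within 1200 nM to 10000 nM.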

Compound 4, half-maximal inhibitory concentration: 2870 nM
Compound 4: middle estimate off by 1.2-fold (0.09 log units), on the high side; the measured number falls inside the stated range.
By their numbers in this assay, from the lowest: compounds 4 and 1 (each within the scatter of the next); then compound 3.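

In this assay, the exchange of acetyl for cyclopropylcarbonyl gives a 1.7-fold lower number from compound 1 to compound 4 (0.22 log units; within the scatter), so compound 1 and compound 4 cannot be told apart. This position on the carbonyl carbon therefore accepts a three-membered carbon ring in place of methyl without a change that can be read in this assay. No available measurement bears on why this is so. From the compounds shown here alone, what remains open is whether a longer chain, a cyclohexyl ring or a chain ending in an amine would be accepted on the same carbonyl carbon. Also open, going by these compounds, is whether cyclopropylcarbonyl would give a similar result on the core of compound 3.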